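Oxane substituent change on the shared core

The source may report more compounds than this note shows. Statements on the series, on what has been measured and on what is new or still open speak of the compounds shown alone.

Measured so far:
compound 1, `COc1ccccc1-n1nc([C@H]2C[C@@H](C)O[C@@H](C)C2)cc1-c1ccc(Cl)cc1`: 3 nM
compound 2, `COc1ccccc1-n1nc(C2C[C@H](C)O[C@@H](C)C2)cc1-c1ccc(Cl)cc1`: 2 nM

In an assay on HEK293 cells for inhibition of Voltage-dependent N-type calcium channel subunit alpha-1B (Homo sapiens), read by fluorescence and calcium flux, with a stated time of 5 min (a lower number here means a stronger inhibitor, a higher number a weaker inhibitor), compound 2 holds the lowest of the two numbers; the step of a 1.5-fold lower number from compound 1 to compound 2 (0.18 log units; within the scatter) lies within the scatter, and the pair differ only by the fact that one of compounds 1 and 2 is drawn with a defined configuration and the other without, at the place where they differ. Compound 3 `COc1ccccc1-n1nc([C@@H]2CCO[C@H](C(C)C)C2)cc1-c1ccc(Cl)cc1` carries 2-isopropyloxan-4-yl in place of 2,6-dimethyloxan-4-yl on an aromatic carbon. Going by the values given here, no measured step alters the substituents of the oxane ring; the single step recorded is a stereochemical one and gives no guide to direction or size here. Compound 3 is therefore expected to stay close to compound 2, a step of a 2.0-fold higher number from compound 2 to compound 3 (0.30 log units; within the scatter), with an estimate of 4 nM and a range from 1 nM to 15 nM.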

Compound 3, half-maximal inhibitory concentration: 7 nM
Compound 3: the middle estimate sits 1.8-fold (0.24 log units) below what was measured; the measured number falls inside the stated range.
By their numbers in this assay, from the lowest: compounds 2 and 1 (each within the scatter of the next); then compound 3.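

In this assay a change of the oxane substituent at this position does register: 2-isopropyloxan-4-yl in place of 2,6-dimethyloxan-4-yl gives a 3.5-fold higher number from compound 2 to compound 3 (0.54 log units; beyond the scatter) and also a 2.3-fold higher number from compound 1 to compound 3 (0.37 log units; beyond the scatter), both modest steps, whereas the earlier pair stayed within the scatter. Nothing on record accounts for these steps.

Open, from the compounds shown here alone, is whether the step follows from the isopropyl group itself or from the loss of the 2,6-dimethyl pattern. Also open, going by these compounds, is how an oxane carrying an amine, a carboxylic acid or a longer chain would compare.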